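Fluoro to Hydrogen on the Benzoyl Arm of Compound 3

The source may report more compounds than this note shows. Statements on the series, on what has been measured and on what is new or still open speak of the compounds shown alone.

Of the compounds shown here, three on the shared core have been tested in a functional assay on PC-3 cells (Homo sapiens) for cytotoxicity, read by MTT assay, with a stated time of 48 h; a higher number here means a weaker inhibitor, a lower number a stronger inhibitor. Compound 1 `COc1cc(-c2nnc3n2NC(c2ccco2)C(C(=O)c2cccc(Br)c2)S3)cc(OC)c1OC` gives 63900 nM, and compound 2 `COc1cc(-c2nnc3n2NC(c2ccco2)C(C(=O)c2cccs2)S3)cc(OC)c1OC` gives 46200 nM. Compound 3 `COc1cc(-c2nnc3n2NC(c2ccco2)C(C(=O)c2ccccc2F)S3)cc(OC)c1OC` returns only a limit of this assay, and in this assay compound 3 gives > 100000 nM. Among the compounds with values here, compound 3 therefore stands at the weak end of the measured set, being the one value that sits at the limit of > 100000 nM in this assay, at which 1 of the 3 values shown sits. The measured steps leading there are an at least 1.5-fold higher number from compound 1 to compound 3 (0.19 log units; that floor lies within the scatter) and an at least 2.1-fold higher number from compound 2 to compound 3 (0.33 log units; beyond the scatter), both exchanges of a whole aryl group on the carbonyl carbon, as is a 1.4-fold lower number from compound 1 to compound 2 (0.14 log units; within the scatter). Compound 4 `COc1cc(-c2nnc3n2NC(c2ccco2)C(C(=O)c2ccccc2)S3)cc(OC)c1OC` differs from compound 3 by hydrogen in place of fluoro on an aromatic carbon. Within the data shown here, none of the measured steps removes a single fluoro, so no step of known size bears directly on this change, and no shift beyond the scatter is expected in either direction. Compound 4 is expected near the limit, at 90000 nM with a range from 40000 nM to 200000 nM, which would mean an expected step of an at least 1.1-fold lower number from compound 3 to compound 4 (0.04 log units; that floor lies within the scatter).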

Compound 4, half-maximal inhibitory concentration: 64300 nM
Compound 4: the middle estimate sits 1.4-fold (0.15 log units) above what was measured; low and high end bracket the measured number.
By their numbers in this assay, from the lowest: compounds 2, 1 and 4 (each within the scatter of the next). At a limit, above all of these: compound 3.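

Within the data shown here, compound 3 remains the only compound at a limit of the assay: the limit of > 100000 nM in this assay, at which 1 of the 4 values shown sits. From the compounds shown here alone, with hydrogen in place of fluoro on the aromatic carbon, the number becomes readable, and the step is an at least 1.5-fold lower number from compound 3 to compound 4 (0.19 log units; that floor lies within the scatter), so even its floor does not clear the usual scatter and its true size stays unknown. Compound 4 also sits with the two other readable compounds, with a 1.4-fold higher number from compound 2 to compound 4 (0.14 log units; within the scatter) and a 1.0-fold higher number from compound 1 to compound 4 (0.00 log units; within the scatter), so phenyl, thiophen-2-yl and 3-bromophenyl on the carbonyl carbon cannot be told apart in this assay.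

The compounds shown leave open how far compound 3 truly lies from the others. They also leave open whether chloro, methoxy or an amine on this aromatic carbon would move the number beyond the scatter of compound 4.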